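The source may hold more compounds than are shown below. What is called first, only, known or untested is meant among the compounds shown, and "the series" means these compounds.

Working notes on the series: in a functional assay on FM3A cells (Mus musculus) for antiproliferative activity, read by cell counting, with a stated time of 2 days (a lower number here means a stronger inhibitor, a higher number a weaker inhibitor), compound 1 (`COc1cc(C(=O)c2sc(Nc3ccccc3)nc2N)cc(OC)c1OC`) gives 23 nM and compound 2 (`COc1cc(C(=O)c2sc(Nc3ccc(C)cc3)nc2N)cc(OC)c1OC`) gives 15 nM, so these two values lie within the scatter of each other. Compound 3 (`COc1ccc(Nc2nc(N)c(C(=O)c3cc(OC)c(OC)c(OC)c3)s2)cc1`) carries methoxy in place of methyl on an aromatic carbon, para to a large group: methoxy in place of methyl on an aromatic carbon. Going by the values given here, the only measured step, a 1.5-fold lower number from compound 1 to compound 2 (0.19 log units; within the scatter), concerns methyl in place of hydrogen, so it bears on this change only indirectly. No step beyond the scatter is expected in this assay. The estimated step is no change at the digits printed from compound 2 to compound 3 (within the scatter). The expected value for compound 3 is 15 nM, with a range of 6 nM to 35 nM.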

Compound 3, half-maximal inhibitory concentration: 2200 nM
Compound 3: middle estimate off by 150-fold (2.17 log units), on the low side; measured number above the stated range.
By their numbers in this assay, from the lowest: compounds 2 and 1 (each within the scatter of the next); then compound 3.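

In this assay, methoxy on this aromatic carbon, para to a large group, gives a 150-fold higher number from compound 2 to compound 3 (2.17 log units; beyond the scatter) when it replaces methyl, and a 96-fold higher number from compound 1 to compound 3 (1.98 log units; beyond the scatter) when it replaces hydrogen. This position is therefore not indifferent to its substituent, although methyl in place of hydrogen gave only a 1.5-fold lower number from compound 1 to compound 2 (0.19 log units; within the scatter). The large loss attaches to methoxy here, and hydrogen and methyl do not separate.

On these data alone, whether a hydroxyl, an ethoxy group or a chlorine at this carbon would behave like methoxy or like methyl remains open. No measurement given here accounts for the size of this step.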